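The source may report more compounds than this note shows. Statements on the series, on what has been measured and on what is new or still open speak of the compounds shown alone.

Three members of the series carry an amino group on the saturated chain attached to an oxygen on an aromatic ring of the shared core. Compound 1 `CCN(CC)CCCOc1cc(O)c2c(=O)cc(-c3ccccc3)oc2c1OC` gives 1830 nM in a functional assay on A549 cells (Homo sapiens) for cytotoxicity, read by MTT assay, with a stated time of 48 h; on this read-out higher numbers stand for weaker inhibition and lower numbers for stronger inhibition. Compound 2 `COc1c(OCCCN2CCN(C)CC2)cc(O)c2c(=O)cc(-c3ccccc3)oc12` gives 9900 nM in this assay, and compound 3 `COc1c(OCCCNCc2ccccc2)cc(O)c2c(=O)cc(-c3ccccc3)oc12` gives 1570 nM in this assay. Among these three numbers compound 3 holds the lowest, but its nearest neighbour is compound 1, the two lying within the scatter as the step of a 1.2-fold lower number from compound 1 to compound 3 (0.07 log units; within the scatter) shows; the steps of a 5.4-fold higher number from compound 1 to compound 2 (0.73 log units; beyond the scatter) and a 6.3-fold lower number from compound 2 to compound 3 (0.80 log units; beyond the scatter) are the only ones beyond the scatter, so compound 2 alone stands apart on the high side.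

Compound 4 `COc1c(OCc2ncc(C)o2)cc(O)c2c(=O)cc(-c3ccccc3)oc12` differs from compound 3 in one place: 5-methyl-1,3-oxazol-2-yl in place of 2-(benzylamino)ethyl on a saturated chain carbon bound to an oxygen on an aromatic ring. Within the data shown here, none of the measured steps removes the amine or shortens the chain; each exchanges one amine for another, and the spread they cover runs from within the scatter to modest. Compound 4 therefore falls outside what the measured steps test directly, and an unfavourable outcome cannot be ruled out. The expectation for compound 4 is a modest step toward a higher number, a 2.5-fold higher number from compound 3 to compound 4 (0.41 log units; beyond the scatter), the estimate being 4000 nM with a range from 1000 nM to 16000 nM.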

Compound 4, half-maximal inhibitory concentration: > 100000 nM
Compound 4 was reported as a limit (the forecaster's own chance of this, stated with the estimate: 15%); middle value at least 25-fold (1.39 log units) from the limit.
By their numbers in this assay, from the lowest: compounds 3 and 1 (each within the scatter of the next); then compound 2. At a limit, above all of these: compound 4.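

Compound 4 is reported only as a limit of the assay, not as a number: the limit of > 100000 nM in this assay, at which 1 of the 4 values shown sits. Replacing the amine-bearing chain with 5-methyl-1,3-oxazol-2-yl gives an at least 63-fold higher number from compound 3 to compound 4 (1.80 log units; beyond the scatter), an at least 54-fold higher number from compound 1 to compound 4 (1.73 log units; beyond the scatter) and an at least 10-fold higher number from compound 2 to compound 4 (1.00 log units; beyond the scatter). Among these compounds, on this saturated chain carbon bound to an oxygen on an aromatic ring, the earlier steps exchanged only one amine for another, whereas this change moves the read-out further than any of them, whichever amine leaves.

This single change removes the amine, shortens the chain and brings in the oxazole ring all at once, so the compounds shown do not separate these parts. Open comparisons are a benzyl ether with no amine, an amine on a shorter chain, and 5-methyl-1,3-oxazol-2-yl on a longer chain.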